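Chloro addition on the pendant phenyl of compound 2

This account rests on a few compounds, and the source may have more. Where it says the series, first, only, none or still open, it means among the compounds named here.

Compound 2 `COc1cc(CSc2cc(Cl)c(-c3nc(-c4ccccc4)no3)cc2S(=O)(=O)NC(=N)NO)cc(OC)c1OC` sits highest in a functional assay on UACC-257 cells (Homo sapiens) (on this read-out lower numbers stand for stronger inhibition of growth and higher numbers for weaker inhibition of growth), at 13200 nM. Compound 1 `N=C(NO)NS(=O)(=O)c1cc(-c2nnc(-c3ccc(Cl)cc3)s2)c(Cl)cc1SCc1ccccc1` gives 2100 nM and compound 3 `N=C(NO)NS(=O)(=O)c1cc(-c2nc(-c3ccccc3)no2)c(Cl)cc1SCc1ccccc1` gives 1680 nM, so compound 2 lies beyond the scatter above both. Compound 4 `COc1cc(CSc2cc(Cl)c(-c3nc(-c4ccc(Cl)cc4)no3)cc2S(=O)(=O)NC(=N)NO)cc(OC)c1OC` is obtained from compound 2 by chloro in place of hydrogen on an aromatic carbon. For the measured compounds named here, the one step measured, a 7.9-fold lower number from compound 2 to compound 3 (0.90 log units; beyond the scatter), concerns the group on the saturated chain carbon bound to a sulfur and does not touch the changed position. Going by the values given here, compound 1 and compound 3 differ in two places, one of them this same chloro, and no single step between them is available; their values stand within the scatter of each other, which gives no sign that the chloro alone moves this assay. The expectation for compound 4 is therefore a step of a 1.3-fold lower number from compound 2 to compound 4 (0.12 log units; within the scatter) that stays within the scatter, with at most a slight drop. Compound 4 is estimated at 10000 nM, with a range from 4000 nM to 30000 nM.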

Compound 4, concentration for 50% growth inhibition: 9330 nM
Compound 4: middle estimate off by 1.1-fold (0.03 log units), on the high side; the measured number falls inside the stated range.
By their numbers in this assay, from the lowest: compounds 3 and 1 (each within the scatter of the next); then compounds 4 and 2 (each within the scatter of the next).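

The change from phenyl to 4-chlorophenyl can now be read alone in this assay: a 1.4-fold lower number from compound 2 to compound 4 (0.15 log units; within the scatter) leaves compound 2 and compound 4 within the scatter of each other. Until now the chloro appeared only together with a second difference, between compound 1 and compound 3, so this is its first single-step reading, and it holds for the 3,4,5-trimethoxyphenyl background only. No measurement at hand explains this outcome.

Still open, going by these compounds, is whether the chloro reads the same way with the plain phenyl on the saturated chain carbon bound to a sulfur, as in compound 3. Also open, on these data alone, is whether a different group at this position, such as an amine or a carboxylic acid, would give a step beyond the scatter.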